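The source may hold more compounds than are shown below. What is called first, only, known or untested is meant among the compounds shown, and "the series" means these compounds.

Working notes on the series. The two measured compounds are compound 1 `CCCCCC(=O)N1CCN(c2nnc3nncn3n2)CC1` and compound 2 `CN(C)c1nnc2nncn2n1`, both carrying the same core. In a functional assay on BeWo cells (Homo sapiens) for inhibition, read by MTT assay, with a stated time of 72 h (on this read-out lower numbers stand for stronger inhibition and higher numbers for weaker inhibition), compound 1 gives 2960 nM, and in this assay compound 2 gives 610 nM. Compound 1 therefore stands at the highest number of the two; the nearest value, that of compound 2, lies lower by more than the scatter of repeated measurements. For the measured compounds named here, no pair differing in a single place has been measured, so no measured step is available to guide the next move.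

The unmeasured compound 3 `CCCC(=O)N1CCN(c2nnc3nncn3n2)CC1` keeps the core and the acylated piperazine of compound 1 and differs from it only by hydrogen in place of ethyl on a saturated chain carbon, three bonds along the chain from a carbonyl carbon. The chain carrying the carbonyl is thus shortened, and nothing else moves. With no measured step of this kind in hand, the expectation rests on compound 1 alone, from which compound 3 is expected to sit within the scatter, a 1.0-fold higher number from compound 1 to compound 3 (0.01 log units; within the scatter), with no direction claimed. Compound 3 is estimated at 3000 nM, within a range of 1000 nM to 9000 nM.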

Compound 3, half-maximal inhibitory concentration: 6730 nM
Beside the measured number, compound 3's estimate is 2.2-fold (0.35 log units) below it; measured number inside the range.
By their numbers in this assay, from the lowest: compound 2; then compound 1; then compound 3.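

For the compounds shown here, this is the first measured step. In this assay, hydrogen in place of ethyl on a saturated chain carbon, three bonds along the chain from a carbonyl carbon, gives a 2.3-fold higher number from compound 1 to compound 3 (0.36 log units; beyond the scatter), a modest step towards weaker inhibition. Going by these compounds alone, the position therefore responds to this change: going from pentyl to propyl on the carbonyl loses some inhibition, which the earlier compounds, with no pair differing in one place, could not show. Nothing measured here bears on the reason for the step.

As far as these compounds go, one pair gives a direction for this single change and no trend, so it remains open whether a longer chain than pentyl would strengthen inhibition further or whether the numbers would level off or reverse. Also open, from the compounds shown here alone, is how a methyl on the carbonyl, or an amine or a carboxylic acid in place of the ethyl, would read in this assay.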